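Working notes on tolerated concentration in a shared-core amine series

This account rests on a few compounds, and the source may have more. Where it says the series, first, only, none or still open, it means among the compounds named here.

Compound 1 `Cc1ccc2nc(N3CCCc4ccc(F)cc4C3)cc(NCC3(N)COC3)c2c1` stands at the top of the numbers shown. In an ADME assay on HEp-2 cells (Homo sapiens) for cytotoxicity, read by CCK-8 assay, with a stated time of 5 days (a lower number here means that less compound is tolerated, a higher number that more compound is tolerated), compound 1 gives > 100000 nM, which is a limit of this assay and not a number (the limit of > 100000 nM in this assay, at which 1 of the 3 values shown sits). Compound 2 `NCC(O)CNc1cc(N2Cc3ccccc3C2)nc2ccccc12` gives 2900 nM in this assay. Compound 3 `NCCNc1cc(N2CCCc3ccccc3C2)nc2ccc(Cl)cc12` also sits at a limit in this assay, giving > 3200 nM (the limit of > 3200 nM in this assay, at which 1 of the 3 values shown sits). Within the data shown here, no two measured compounds differ in a single place, so no computed step is available among them.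

Compound 4 `CNCCNc1cc(N2CCCc3ccc(F)cc3C2)nc2ccc(C)cc12` differs from compound 1 by (methylamino)methyl in place of 3-aminooxetan-3-yl on a saturated chain carbon bound to a nitrogen on an aromatic ring. Compound 4 has not yet been measured in this assay. Compound 4 is estimated at 30000 nM, expected to fall between 5000 nM and 100000 nM. The expected step, downward and beyond the scatter, is an at least 3.3-fold lower number from compound 1 to compound 4 (0.52 log units; beyond the scatter).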

Compound 4, half-maximal cytotoxic concentration: 29000 nM
Compound 4: the middle estimate sits 1.0-fold (0.01 log units) above what was measured; the range from low to high includes it.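

Among these compounds, with the rest of the core of compound 1 held fixed, this is the first change that can be read alone. In this assay, (methylamino)methyl in place of 3-aminooxetan-3-yl on a saturated chain carbon bound to a nitrogen on an aromatic ring gives an at least 3.4-fold lower number from compound 1 to compound 4 (0.53 log units; beyond the scatter). This step is a bound and not an exact size, because compound 1 stands at a limit of the assay: the limit of > 100000 nM in this assay, at which 1 of the 4 values shown sits.

A single pair cannot separate the loss of the four-membered ring from the change in the amine. Also open, as far as these compounds go, is how a carboxylic acid or a dimethylamino group would read at this position.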